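A few compounds are considered here, and "the series" means these few. Any claim that something is new, unique, unknown or untested is made for them only; others in the source may bear on it.

Of the compounds shown here, three have been measured in a functional assay on RBL-2H3 cells (Rattus norvegicus) for inhibition (a lower number here means a stronger inhibitor, a higher number a weaker inhibitor), so far. Compound 1 `Cc1csc(N/C(S)=N/[C@@H](C)c2cccc3ccccc23)n1` gives 83200 nM. Compound 2 `C[C@@H](/N=C(\S)Nc1ccccn1)c1cccc2ccccc12` reaches only the limit of the assay, > 100000 nM, so for it no number is known; this is the limit recorded in the limit of > 100000 nM in this assay, at which 1 of the 3 values shown sits. Compound 3 `Cc1cccc(N/C(S)=N/[C@@H](C)c2cccc3ccccc23)n1` gives 1600 nM, the lowest of the two numbers and therefore the strongest inhibitor among the compounds with a number. Among the measured compounds shown here, the one measured step, a 52-fold lower number from compound 1 to compound 3 (1.72 log units; beyond the scatter), is large and beyond the scatter, and it comes from exchanging the heterocycle on the amine nitrogen.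

Compound 4 `C[C@H](/N=C(\S)Nc1ccccn1)c1cccc2ccccc12` has not been measured. It differs from compound 3 by hydrogen in place of methyl on an aromatic carbon, that is, the 6-methylpyridin-2-yl becomes pyridin-2-yl. For the measured compounds named here, no measured step removes this methyl, so the size of the effect cannot be read from the data; the only step known concerns the ring itself. Given the strength of compound 3 at 1600 nM, compound 4 is estimated to land at 8000 nM, with a likely range from 2000 nM to 40000 nM. This estimate corresponds to an expected step of a 5.0-fold higher number from compound 3 to compound 4 (0.70 log units; beyond the scatter), a weakening.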

Compound 4, half-maximal inhibitory concentration: > 100000 nM
Compound 4 ended at the assay's limit (the forecaster's own chance of this, stated with the estimate: 20%); middle value at least 12-fold (1.09 log units) from the limit.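

Compound 4 gives > 100000 nM in this assay, and this is a limit of the assay, not a number. Among the compounds shown here, the earlier compounds showed only that exchanging one whole ring for another on the amine nitrogen can matter, whereas here a single methyl, on the aromatic carbon next to the ring nitrogen, is the only group that leaves, and the result is an at least 62-fold higher number from compound 3 to compound 4 (1.79 log units; beyond the scatter), so the activity of compound 3 in this series depends heavily on that one small group. The comparison with the thiazole compound is much less informative, since an at least 1.2-fold higher number from compound 1 to compound 4 (0.07 log units; that floor lies within the scatter) gives only a floor, which leaves the order of these two compounds unsettled.

On these data alone, the step between compound 2 and compound 4, which differ only in the configuration drawn at the stereocentre, cannot be read, so any effect of that configuration on the pyridin-2-yl compounds stays open, because both compounds sit at the same limit: the limit of > 100000 nM in this assay, at which 2 of the 4 values shown sit. The compounds shown also leave open whether an ethyl, a methoxy or a chlorine in place of this methyl would keep, lose or improve on the inhibition seen with compound 3.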